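The source may hold more compounds than are shown below. What is called first, only, known or untested is meant among the compounds shown, and "the series" means these compounds.

In a functional assay on COLO 205 cells (Homo sapiens) for inhibition, read by sulforhodamine B assay, with a stated time of 48 h, tested at 50 uM (on this read-out lower numbers stand for less inhibition of growth and higher numbers for more inhibition of growth at the one concentration tested), compound 2 `COc1cc(/C=C/C(=O)/C=C/c2ccco2)ccc1OCc1cn(CCCOc2cc(=O)oc3ccccc23)nn1` gives 59%. Compound 1 `COc1cc(/C=C/C(=O)/C=C/c2cccc3ccccc23)ccc1OCc1cn(CCCOc2cc(=O)oc3ccccc23)nn1` gives 64%, and compound 3 `COc1cc(/C=C/C(=O)/C=C/c2ccccc2)ccc1OCc1cn(CCCCOc2cc(=O)oc3ccccc23)nn1` gives 31%. Compound 2 thus sits level with compound 1 within the scatter, while compound 3 lies lower by more than the scatter. Compound 4 `COc1cccc(/C=C/C(=O)/C=C/c2ccc(OCc3cn(CCCOc4cc(=O)oc5ccccc45)nn3)c(OC)c2)c1` differs from compound 2 by 3-methoxyphenyl in place of furan-2-yl on a double-bonded chain carbon bound to a double-bonded chain carbon, with 3-methoxyphenyl in place of furan-2-yl on a double-bonded chain carbon bound to a double-bonded chain carbon. Going by the values given here, only one measured step bears on this place: a number 5 percentage points lower from compound 1 to compound 2 (within the scatter). Compound 3 differs from compound 2 in more than one place, so its value says little about this change. With naphthalen-1-yl and furan-2-yl so close there, no change beyond the scatter is expected in this assay, although a single step is thin evidence. The expected change is a number 1 percentage points lower from compound 2 to compound 4 (within the scatter). Compound 4 is estimated at 58%, with an expected range from 42% to 72%.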

Compound 4, percent growth inhibition at one concentration: 52%
Beside the measured number, compound 4's estimate is 6 percentage points above it; measured number inside the range.
By their numbers in this assay, from the lowest: compound 3; then compounds 4, 2 and 1 (each within the scatter of the next, the first and the last beyond it).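

In this assay, a third aromatic group at this place, 3-methoxyphenyl, adds to the picture: a number 7 percentage points lower from compound 2 to compound 4 (within the scatter), whereas a number 12 percentage points lower from compound 1 to compound 4 (beyond the scatter). This gives the first gap beyond the scatter at this position, a modest one, with compound 2 level with both of the others, so furan-2-yl cannot be separated from either 3-methoxyphenyl or naphthalen-1-yl. Nothing measured here accounts for the gap between 3-methoxyphenyl and naphthalen-1-yl.

All the groups shown at this place are aromatic rings, so it remains open how an amine, a carboxylic acid or a plain alkyl chain would fare there. Compound 3 differs from compound 4 in more than one place, so it cannot show whether the methoxy group of 3-methoxyphenyl matters.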